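The source may report more compounds than this note shows. Statements on the series, on what has been measured and on what is new or still open speak of the compounds shown alone.

Compound 1, `COC(=O)[C@@]1(C)CCC=C2[C@@H]1CC[C@@H](C)[C@]2(C)Cc1c[nH]c2ccc(F)cc12`, and compound 2, `COC(=O)[C@@]1(C)CCC=C2[C@@H]1CC[C@@H](C)[C@]2(C)Cc1c[nH]c2ccc(OC)cc12`, share one core and differ only at one aromatic carbon. In a functional assay on T47D cells (Homo sapiens) for inhibition, read by sulforhodamine B assay, with a stated time of 48 h (a lower number here means a stronger inhibitor of growth, a higher number a weaker inhibitor of growth), compound 1 gives 3900 nM, and compound 2 gives 3700 nM. The change between them is methoxy in place of fluoro on an aromatic carbon, and it made the step of a 1.1-fold lower number from compound 1 to compound 2 (0.02 log units; within the scatter), so the two numbers are not told apart here.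

Compound 3, `COC(=O)[C@@]1(C)CC[C@@H]2C3=C1CC[C@@H](C)[C@]3(C)C[C@@H]1c3cc(F)ccc3N[C@H]21`, is built from the same atoms as compound 1 joined differently; how the two cores differ is not broken down here. In this assay compound 3 gives 27000 nM, the highest of the three numbers, and its distance from both compound 1 and compound 2 lies beyond the usual scatter.

Compound 4, `COC(=O)[C@@]1(C)CC[C@@H]2C3=C1CC[C@@H](C)[C@]3(C)C[C@@H]1c3cc(OC)ccc3N[C@H]21`, stands to compound 3 as compound 2 stands to compound 1: the change is methoxy in place of fluoro on an aromatic carbon. The place differs in that the aromatic ring is part of a fused or bridged system of five rings rather than of two rings, so this is the same kind of change rather than the same change. Because compound 1 to compound 2 gave a 1.1-fold lower number from compound 1 to compound 2 (0.02 log units; within the scatter), the step from compound 3 to compound 4 is expected to be similarly small, a 1.1-fold lower number from compound 3 to compound 4 (0.03 log units; within the scatter). Compound 4 is therefore estimated to give about 25000 nM in this assay, most likely between 12000 nM and 55000 nM.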

Compound 4, concentration for 50% growth inhibition: 19000 nM
For compound 4 the middle estimate is 1.3-fold (0.12 log units) above the measured one; low and high end bracket the measured number.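

In this assay, carrying methoxy in place of fluoro on an aromatic carbon over to the core of compound 3 gave a 1.4-fold lower number from compound 3 to compound 4 (0.15 log units; within the scatter), and this step can be set beside the one seen on the core of compound 1: the same change on two cores in this assay, a 1.1-fold lower number (0.02 log units; within the scatter) from compound 1 to compound 2 and a 1.4-fold lower number (0.15 log units; within the scatter) from compound 3 to compound 4, 1.3-fold (0.13 log units) apart, within the scatter of two such steps For these two pairs, the change therefore carried over from one core to the other, leaving the number within the scatter each time, with no difference between the cores that this measurement could tell apart. This agreement is limited, however, as neither step produced a change beyond the scatter, so the pairs do not show whether a larger effect would carry across these cores, and they say nothing about other changes, other places on the ring, or other assays.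

The compounds shown leave open whether an amine or a carboxylic acid on this aromatic carbon, or a longer chain such as butoxy in place of methoxy, would shift the number on either core. They also leave open what would follow if the methyl ester shared by all four compounds were replaced by a carboxylic acid or an amide.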